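The source may hold more compounds than are shown below. What is called first, only, known or untested is meant among the compounds shown, and "the series" means these compounds.

Measured so far:
- compound 1, `Cc1ccc(C2(c3ccc(O)cc3)C(=O)Nc3c2ccc(F)c3F)cc1`: 0.8 nM
- compound 2, `O=C1Nc2c(ccc(F)c2F)C1(c1ccc(O)cc1)c1ccc(F)c(F)c1`: 19 nM

Both compounds were tested in a functional assay on PC-3 cells (Homo sapiens) for cytotoxicity, read by WST assay, with a stated time of 72 h; on this read-out higher numbers stand for weaker inhibition and lower numbers for stronger inhibition. Compound 1 gives the lowest of the two numbers: its nearest neighbour is compound 2, and the change of 3,4-difluorophenyl in place of 4-methylphenyl on a saturated ring carbon brings a 24-fold higher number from compound 1 to compound 2 (1.38 log units; beyond the scatter).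

The compound not yet measured is compound 3, `O=C1Nc2c(ccc(F)c2F)C1(CC1CCCCC1)c1ccc(O)cc1`. It differs from compound 1 at the same saturated ring carbon:

cyclohexylmethyl in place of 4-methylphenyl on a saturated ring carbon

Among the measured compounds shown here, the only measured step that bears on this position is the one from compound 1 to compound 2, a 24-fold higher number from compound 1 to compound 2 (1.38 log units; beyond the scatter), which shows that replacing the 4-methylphenyl group there is not a neutral change. That step swapped one aromatic ring for another; the present change exchanges the aromatic ring for a non-aromatic one with an added carbon, a larger departure from compound 1 than the step measured so far. A clearly weaker inhibition in this assay is therefore expected for compound 3, with the size of the step uncertain: the expectation is a 38-fold higher number from compound 1 to compound 3 (1.57 log units; beyond the scatter). Compound 3 is estimated at 30 nM, with a likely range from 4 nM to 300 nM.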

Compound 3, half-maximal inhibitory concentration: > 1000 nM
Compound 3 ended at the assay's limit (the forecaster's own chance of this, stated with the estimate: 5%); at least 33-fold (1.52 log units) between middle value and limit.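

In this assay the result for compound 3 is a limit of the assay, not a number: the limit of > 1000 nM in this assay, at which 1 of the 3 values shown sits. Exchanging 4-methylphenyl for cyclohexylmethyl keeps the same number of heavy atoms yet gives an at least 1200-fold higher number from compound 1 to compound 3 (3.09 log units; beyond the scatter), so the count of atoms in the group does not by itself decide the outcome at this saturated ring carbon. Replacing the 3,4-difluorophenyl group with the same cyclohexylmethyl gives an at least 52-fold higher number from compound 2 to compound 3 (1.72 log units; beyond the scatter), so among these three compounds, the two with an aromatic ring on this carbon both give far lower numbers than the one with a non-aromatic ring.

Cyclohexylmethyl differs from the aromatic groups in two ways at once, in its non-aromatic ring and in the extra carbon that links this ring to the core, and the compounds shown cannot separate these two changes; a cyclohexyl group joined directly to the core, or a benzyl group, would bear on that question. Also open, on these data alone, is how this position would respond to a pyridine ring or to a group carrying an amine.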